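Methoxy in Place of Hydrogen: Expected Cytotoxicity of Compound 3

A few compounds are considered here, and "the series" means these few. Any claim that something is new, unique, unknown or untested is made for them only; others in the source may bear on it.

Compound 1 `O=C(Nc1cccc(C(F)(F)F)c1)Nc1cccc2c(Oc3ccc([N+](=O)[O-])cc3)cccc12` — 953 nM
Compound 2 `O=C(Nc1ccccc1)Nc1cccc2c(Oc3ccc([N+](=O)[O-])cc3)cccc12` — 953 nM

In a functional assay on MCF7 cells (Homo sapiens) for cytotoxicity, read by MTT assay, with a stated time of 24 h (on this read-out lower numbers stand for stronger inhibition and higher numbers for weaker inhibition), compound 1 gives 953 nM and compound 2 gives 953 nM, so compound 2 stands level with compound 1. Going by the values given here, the only measured step, no change at the digits printed from compound 1 to compound 2 (within the scatter), shows that swapping the trifluoromethyl for hydrogen on that aromatic carbon left the read-out unchanged. Compound 3 `COc1ccc(NC(=O)Nc2cccc3c(Oc4ccc([N+](=O)[O-])cc4)cccc23)cc1` differs from compound 2 by methoxy in place of hydrogen on an aromatic carbon. Among the compounds with values here, no measured step involves a methoxy, so the precedent is indirect, but one change at this position had no effect. Compound 3 is therefore expected to show a 1.0-fold lower number from compound 2 to compound 3 (0.00 log units; within the scatter), no change beyond the scatter. Compound 3 is estimated at 950 nM, between 400 nM and 2200 nM.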

Compound 3, half-maximal inhibitory concentration: 953 nM
For compound 3 the middle estimate is 1.0-fold (0.00 log units) below the measured one; the range from low to high includes it.
By their numbers in this assay, from the lowest: compounds 1, 2 and 3 (each within the scatter of the next).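

In this assay, methoxy now has a direct precedent on this ring, with no change at the digits printed from compound 2 to compound 3 (within the scatter). Exchanging 3-(trifluoromethyl)phenyl for 4-methoxyphenyl on the amide-type nitrogen also reads no change at the digits printed from compound 1 to compound 3 (within the scatter), so all three aryl groups shown on this nitrogen give the same printed value. Nothing available offers an explanation for this sameness.

The compounds shown leave open whether any group at this position would move the read-out. An amine or a carboxylic acid on this ring could still read differently.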